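A few compounds are considered here, and "the series" means these few. Any claim that something is new, unique, unknown or untested is made for them only; others in the source may bear on it.

For the measured compounds named here, in an ADME assay on the whole organism (strain CD-1) for pharmacokinetics, with Mus musculus as the target, at a dose of 3 mg/kg by the intravenous route (on this read-out higher numbers stand for fast clearance and lower numbers for slow clearance), compound 2 (`C[C@@H](CCCOc1ccccc1CN(C)C(=O)c1ccc(-c2ccco2)cc1)CC(=O)O`) gives 1.3 mL/min/kg, the lower of the two numbers so far, while compound 1 (`CN(Cc1ccccc1OCCCCCC(=O)O)C(=O)c1ccc(-c2ccco2)cc1`) gives 44 mL/min/kg. Compound 3 (`C/C(=C\C(=O)O)CCCOc1ccccc1CN(C)C(=O)c1ccc(-c2ccco2)cc1`) differs from compound 2 by 2-carboxy-1-methylethenyl in place of 1-(carboxymethyl)ethyl on a saturated chain carbon, three bonds along the chain from an oxygen on an aromatic ring. Going by the values given here, one measured step bears on this: a 34-fold lower number from compound 1 to compound 2 (1.53 log units; beyond the scatter), a large step that came with methyl in place of hydrogen on a saturated chain carbon. Compound 3 still carries a methyl in its 2-carboxy-1-methylethenyl group, so no step beyond the scatter is expected, though any shift is expected to be upward. The estimated step is a 1.9-fold higher number from compound 2 to compound 3 (0.28 log units; within the scatter). Compound 3 is estimated at 2.5 mL/min/kg, with an expected range from 0.8 mL/min/kg to 10 mL/min/kg.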

Compound 3, clearance: 11 mL/min/kg
Beside the measured number, compound 3's estimate is 4.4-fold (0.64 log units) below it; measured number above the stated range.
By their numbers in this assay, from the lowest: compound 2; then compound 3; then compound 1.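

In this assay, the methyl alone does not hold the low clearance of compound 2: with the saturated 1-(carboxymethyl)ethyl replaced by 2-carboxy-1-methylethenyl, there is an 8.5-fold higher number from compound 2 to compound 3 (0.93 log units; beyond the scatter) at this place. The methyl-bearing unsaturated chain still leaves a 4.0-fold lower number from compound 1 to compound 3 (0.60 log units; beyond the scatter), so compound 3 lies between the other two. Nothing measured here explains this shift. The compounds shown leave open how the opposite configuration at the methyl-bearing carbon would read, and whether a second methyl or a cyclopropane ring there would stand nearer compound 2 or compound 3.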